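Shortening the Chain of Compound 2

The compounds below may be only part of what the source reports. "The series", "measured", "known", "first", "only" and "open" are said of these compounds alone.

In a functional assay on HepG2 cells (Homo sapiens) for inhibition, read by MTT assay, with a stated time of 72 h (a higher number here means a weaker inhibitor, a lower number a stronger inhibitor), compound 1 (`CNC(=O)CCCCCCCn1nc(-c2cnc3[nH]ccc3c2)c2c(N)ncnc21`) gives 5630 nM. Compound 2 (`Nc1nc2cc(-c3nn(CCCCCCCCCC(=O)NO)c4ncnc(N)c34)ccc2o1`) gives 28600 nM, the higher of these two numbers and so the weaker inhibitor, with a gap beyond the usual scatter.

Compound 3 (`Nc1nc2cc(-c3nn(CCCCCCC(=O)NO)c4ncnc(N)c34)ccc2o1`) keeps the core of compound 2 but has a shorter chain, with hydroxycarbamoyl in place of 3-(hydroxycarbamoyl)propyl on a saturated chain carbon, six bonds along the chain from an aromatic nitrogen. Among the compounds with values here, no measured pair isolates this change, so any forecast is loose. Within the data shown here, the only guide is a chain also shorter than that of compound 2, though with a different core and end group, in compound 1 at 5630 nM. A moderate fall in this assay is therefore expected, beyond the scatter, and the estimated step of a 3.2-fold lower number from compound 2 to compound 3 (0.50 log units; beyond the scatter) points towards stronger inhibition. For compound 3, the expected value is 9000 nM, with an estimated range of 2000 nM to 30000 nM.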

Compound 3, half-maximal inhibitory concentration: 1610 nM
Compound 3: the middle estimate sits 5.6-fold (0.75 log units) above what was measured; the measured number lies below the stated range.
By their numbers in this assay, from the lowest: compound 3; then compound 1; then compound 2.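

In this assay, within the data shown here, this is the first pair that isolates the chain at this position: hydroxycarbamoyl in place of 3-(hydroxycarbamoyl)propyl, on a saturated chain carbon, six bonds along the chain from an aromatic nitrogen, gives a large step (an 18-fold lower number from compound 2 to compound 3 (1.25 log units; beyond the scatter)). The shared core and the hydroxycarbamoyl end stay the same in this pair, so the stronger inhibition is tied to the chain alone, which compound 1, differing in more than one place, could not show. Nothing available explains why the shorter chain goes with stronger inhibition.

Two compounds cannot tell whether potency keeps rising as the chain shortens or peaks at some intermediate length. On these data alone, whether a still shorter chain would do better, or whether a carboxylic acid or an amine could replace the hydroxycarbamoyl end on this chain, also remains open.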